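The source may hold more compounds than are shown below. What is called first, only, known or untested is meant among the compounds shown, and "the series" means these compounds.

Measured compounds:
- Compound 1 `CN(c1ccc(Oc2ncnc3ccsc23)cc1)c1nccc(N2CCc3ccccc3C2)n1`: 30.2%
- Compound 2 `CN(c1ccc(Oc2ncnc3ccsc23)cc1)c1nccc(N2CCCCC2)n1`: 49.7%
- Compound 3 `CN(c1ccc(Oc2ncnc3sccc23)cc1)c1nccc(N2CCCCC2)n1`: 29.3%

These three compounds were compared in a functional assay on MDA-MB-231 cells (Homo sapiens) for inhibition, read by MTT assay, with a stated time of 72 h, tested at 20 uM; on this read-out lower numbers stand for less inhibition and higher numbers for more inhibition at the one concentration tested (going by the name of the read-out). Compound 2 stands highest of the three. Its nearest neighbour is compound 1, and the step between them was a number 19.5 percentage points higher from compound 1 to compound 2 (beyond the scatter). The step to compound 3 was a number 20.4 percentage points lower from compound 2 to compound 3 (beyond the scatter). Both steps are modest, and both concern parts of the molecule that compound 4 leaves unchanged.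

Compound 4 `c1cc(N2CCCCC2)nc(Nc2ccc(Oc3ncnc4ccsc34)cc2)n1` is not yet measured. It differs from compound 2 in one place: hydrogen in place of methyl on a nitrogen on an aromatic ring. Among the compounds with values here, none of the measured steps touches this nitrogen, so there is no direct guide to how much this change matters. The only knowledge at hand is that single changes elsewhere in this series moved the read-out by modest amounts, and that the three measured numbers all fall in a middling band. Within the data shown here, with no step bearing on the change itself, the reasonable expectation for compound 4 is a number close to compound 2, with the possibility of a modest move in either direction.

The step from compound 2 to compound 4 is expected to be a number 4.7 percentage points lower from compound 2 to compound 4 (within the scatter). Compound 4 is therefore estimated at 45%, within a range from 25% to 65%.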

Compound 4, a percentage reported as inhibition, at one concentration (the size of the read-out at that concentration, not a potency): 45.7%
Beside the measured number, compound 4's estimate is 0.7 percentage points below it; the measured number falls inside the stated range.
By their numbers in this assay, from the lowest: compounds 3 and 1 (each within the scatter of the next); then compounds 4 and 2 (each within the scatter of the next).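

In this assay hydrogen in place of methyl on the nitrogen gives a number 4 percentage points lower from compound 2 to compound 4 (within the scatter) and so leaves the read-out unchanged within the usual scatter. Within the data shown here, the two earlier single changes behaved differently: the swap on the aromatic carbon gave a number 19.5 percentage points higher from compound 1 to compound 2 (beyond the scatter) and the swap on the oxygen gave a number 20.4 percentage points lower from compound 2 to compound 3 (beyond the scatter) and both lie beyond the scatter, so this nitrogen is the first place where a single change has no clear effect, and the methyl there is not needed to keep the number at this level. No information is available to explain why the methyl can go without a clear change in the number.

Going by these compounds, whether an ethyl group, a longer chain or an acetyl group on this nitrogen would also keep the number at this level stays open, as does whether hydrogen in place of methyl would behave alike with the 1,2,3,4-tetrahydroisoquinolin-2-yl group of compound 1 or the core of compound 3. On these data alone, a read-out at one concentration is also not a potency, so any difference between compound 2 and compound 4 at other concentrations remains unknown.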